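The source may report more compounds than this note shows. Statements on the series, on what has been measured and on what is new or still open speak of the compounds shown alone.

Compound 1 `COc1cc(C#N)ccc1OCc1nnc(-c2ccccc2)o1` and compound 2 `COc1ccc(-c2nnc(COc3ccc(C#N)cc3OC)o2)cc1` share one core and were both tested in an ADME assay on MCF-10A cells (Homo sapiens) for cytotoxicity, read by MTT assay, with a stated time of 48 h; a higher number here means a weaker inhibitor, a lower number a stronger inhibitor. In this assay compound 1 gives only a limit, > 100000 nM. Compound 2 likewise gives only a limit in this assay, > 100000 nM. The change between the two is methoxy in place of hydrogen on an aromatic carbon, and the measured step is a step that the two limits leave unreadable from compound 1 to compound 2, since both values sit at the limit of > 100000 nM in this assay, at which 3 of the 3 values shown sit. Compound 3 `N#Cc1ccc(OCc2nnc(-c3ccccc3)o2)cc1F` carries a different core; the difference between the two cores is not broken down here. In this assay compound 3 also gives only a limit, > 100000 nM. Compound 4 `COc1ccc(-c2nnc(COc3ccc(C#N)c(F)c3)o2)cc1` differs from compound 3 by methoxy in place of hydrogen on an aromatic carbon, the same change as that between compound 1 and compound 2, made at the same place. Among the compounds with values here, because the limit of > 100000 nM in this assay, at which 3 of the 3 values shown sit, holds all three values so far, the step that the limit leaves unreadable from compound 3 to compound 4 is expected to leave the reading at that limit rather than move it in a readable way. For compound 4 the estimate is therefore 150000 nM, with a range from 60000 nM to 500000 nM, and most likely only a limit will be reported.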

Compound 4, half-maximal inhibitory concentration: > 100000 nM
Compound 4 gave a limit, no number; the forecaster's own chance of this, stated with the estimate: 85%; the middle value is on the limit's open side.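

No step can be read between compound 3 and compound 4, because each gives only a limit and not a number: the limit of > 100000 nM in this assay, at which 4 of the 4 values shown sit.

The compounds shown leave open whether the change from phenyl to 4-methoxyphenyl has any effect in this assay, and how far the true value of each compound lies beyond the limit.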